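Working notes on a small channel-inhibitor series

The source may hold more compounds than are shown below. What is called first, only, known or untested is meant among the compounds shown, and "the series" means these compounds.

Measured so far in an assay on HEK293 cells for inhibition of transient receptor potential cation channel subfamily V member 6 (Homo sapiens), read by FLIPR, with a stated time of 5 min; a higher number here means a weaker inhibitor, a lower number a stronger inhibitor:
compound 1 `c1ccc([B-]2(c3ccccc3)[NH2+]CCS2)cc1`; compound 1 gives 93500 nM
compound 2 `COc1ccccc1[B-]1(c2ccccc2OC)[NH2+]CCO1`; compound 2 gives 412000 nM
compound 3 `Fc1ccc([B-]2(c3ccc(F)cc3)[NH2+]CCO2)cc1`; compound 3 gives 14200 nM

Compound 3 holds the lowest of the three numbers in this assay. Its gap to compound 1 is beyond the scatter, and its gap to compound 2 is wider still and also beyond the scatter. Compound 2 shows the highest number of the three.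

The next compound, compound 4 `Fc1ccc([B-]2(c3ccccc3)[NH2+]CCO2)cc1`, differs from compound 3 by hydrogen in place of fluoro on an aromatic carbon, para to a large group. Among the measured compounds shown here, no measured pair isolates this single change. For the measured compounds named here, compound 1 carries no fluoro on either aromatic ring, but it also differs from compound 3 in the atom of the small ring, so its value gives no clean read on the fluoro alone; it shows only that a fluoro-free member of the series sits higher than compound 3.

The step from compound 3 to compound 4 is expected to be a modest rise in this assay, near the edge of the scatter, a 2.1-fold higher number from compound 3 to compound 4 (0.32 log units; beyond the scatter). Compound 4 is estimated at 30000 nM, with a range from 10000 nM to 100000 nM.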

Compound 4, half-maximal inhibitory concentration: 33600 nM
Compound 4: the middle estimate sits 1.1-fold (0.05 log units) below what was measured, and the stated range covers the measured number.
By their numbers in this assay, from the lowest: compound 3; then compound 4; then compound 1; then compound 2.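

In this assay, the change of hydrogen in place of fluoro on an aromatic carbon, para to a large group, now has a clean read: a 2.4-fold higher number from compound 3 to compound 4 (0.37 log units; beyond the scatter), a modest step beyond the scatter. The earlier compounds shown here could not separate the fluoro from other differences, whereas this pair changes nothing else, so the loss of this one fluoro alone is enough to raise the number. The second fluoro of compound 3 is absent here while the fluoro on the other ring stays in place, so the step describes one ring only, and nothing in hand explains its size or direction.

The compounds shown leave open whether removing the remaining fluoro would give a step of similar size, and whether the sulfur and oxygen of the small ring differ once the aromatic rings are held the same. They also leave open whether the fluoro is special at this position or whether a chloro, a nitrile or a trifluoromethyl group placed there would hold the number as low as in compound 3.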